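Indole-oxadiazole series: N-methylation of compound 3

The compounds below may be only part of what the source reports. "The series", "measured", "known", "first", "only" and "open" are said of these compounds alone.

Measured so far in a functional assay on MDA-MB-231 cells (Homo sapiens) for cytotoxicity, read by MTT assay; on this read-out higher numbers stand for weaker inhibition and lower numbers for stronger inhibition:
- compound 1, `c1ccc(-c2nnc(-c3c[nH]c4ccccc34)o2)cc1` — > 1000000 nM
- compound 2, `COc1ccc(-c2nnc(-c3c[nH]c4ccccc34)o2)cc1OC` — > 1000000 nM
- compound 3, `COc1cc(-c2nnc(-c3c[nH]c4ccccc34)o2)ccc1OCc1ccccc1` — > 1000000 nM

Each of these values is a limit of this assay and not a number. Compound 3 therefore stands only at a limit, and no position for it among the other two can be read. Going by the values given here, the one change between measured compounds that touches compound 3 is a step that the two limits leave unreadable from compound 2 to compound 3; with both ends at a limit its size is not readable. Among the compounds with values here, the only evidence available is the limit of > 1000000 nM in this assay, at which 3 of the 3 values shown sit, which says that every value so far sits at that limit and nothing more.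

Compound 4, `COc1cc(-c2nnc(-c3cn(C)c4ccccc34)o2)ccc1OCc1ccccc1`, differs from compound 3 by methyl in place of hydrogen on an aromatic nitrogen. Within the data shown here, no measured step bears on a change at this position, since all three values shown are limits and no readable step exists. What is expected rests solely on compound 3 sitting at > 1000000 nM: the most likely outcome is that compound 4 also reports a limit rather than a number. On that basis compound 4 is estimated at 1500000 nM, with a range from 300000 nM to 10000000 nM, which would mean an expected step that the limit leaves unreadable from compound 3 to compound 4.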

Compound 4, half-maximal inhibitory concentration: > 1000000 nM
Compound 4 ended at the assay's limit; the forecaster's own chance of this, stated with the estimate: 80%; the middle value is on the limit's open side.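

In this assay compound 4 gives > 1000000 nM, which is a limit of the assay and not a number. No step can be read between compound 3 and compound 4, as both stand only at a limit. Left open is whether any compound of this series gives a readable number, and what methyl in place of hydrogen on an aromatic nitrogen does to the value.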